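The source may report more compounds than this note shows. Statements on the series, on what has been measured and on what is new or still open speak of the compounds shown alone.

Measured so far in an ADME assay on Vero cells (Chlorocebus sabaeus) for cytotoxicity; on this read-out lower numbers stand for higher toxicity in this test and higher numbers for lower toxicity in this test:

- compound 2 `COc1ccc(-c2nc3cc(Cl)c(Cl)cc3[nH]2)cc1`: 30000 nM
- compound 1 `COc1ccc(-c2nc3cc(C(F)(F)F)ccc3[nH]2)c(OC)c1OC`: 70000 nM
- compound 3 `C#C[C@@]1(O)[C@H](O)[C@@H](CO)O[C@H]1n1ccc(N)nc1=O`: > 100000 nM (a limit of the test, not a number)

Of the two numbers obtained, compound 2 gives the lowest in this assay; the nearest is compound 1, whose higher number lies beyond the usual scatter. Compound 3 is reported only as a limit in this assay, so it gives no number to compare. Among the measured compounds shown here, the shared core of compound 1 and compound 2 carries different substituents on both rings, and no pair among the measured compounds differs in one place, so no measured step is available to read off.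

Compound 4 `Oc1ccc(-c2nc3cc(Cl)c(Cl)cc3[nH]2)cc1` differs from compound 2 in a single place: hydrogen in place of methyl on an oxygen on an aromatic ring. The change is small, a single heavy atom leaving. Such a change is expected to move the number in this assay by no more than the scatter, in either direction. For compound 4 the expected value in this assay is 35000 nM, with a range from 15000 nM to 90000 nM, which means a step from compound 2 to compound 4 of a 1.2-fold higher number from compound 2 to compound 4 (0.07 log units; within the scatter), expected to stay within the scatter.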

Compound 4, half-maximal cytotoxic concentration: 18000 nM
Compound 4: the middle estimate sits 1.9-fold (0.29 log units) above what was measured, within the range that was stated.
By their numbers in this assay, from the lowest: compounds 4 and 2 (each within the scatter of the next); then compound 1. At a limit, above all of these: compound 3.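

In this assay, among the compounds shown here, hydrogen in place of methyl on an oxygen on an aromatic ring gives a 1.7-fold lower number from compound 2 to compound 4 (0.22 log units; within the scatter) and provides the first step that can be read at a single place. With the rest of compound 2 unchanged, methoxy and hydroxy at this place cannot be told apart in this test, and both compounds give numbers rather than limits. Nothing measured here bears on a cause for this step.

Going by these compounds, it remains open whether a longer chain on this oxygen, or an amine or a carboxylic acid at this place, would move the number beyond the scatter. On these data alone, it is also open whether methoxy to hydroxy reads the same way on compound 1, whose substituents differ from those of compound 2 on both rings.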